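Aryl swap at the five-membered ring: compound 3 to compound 4

A few compounds are considered here, and "the series" means these few. Any claim that something is new, unique, unknown or untested is made for them only; others in the source may bear on it.

Compound 3 `CN(C)c1ncnc2c1c(-c1ccoc1)cn2[C@@H]1O[C@H](CO)[C@@H](O)[C@H]1O` gives 1540 nM in a functional assay on K562 cells (Homo sapiens), read by MTT assay, with a stated time of 72 h (a lower number here means a stronger inhibitor, a higher number a weaker inhibitor), the highest of the three numbers; compound 2 `C#Cc1cn([C@@H]2O[C@H](CO)[C@@H](O)[C@H]2O)c2ncnc(N(C)C)c12` gives 110 nM and compound 1 `COc1ncnc2c1c(-c1cccs1)cn2[C@@H]1O[C@H](CO)[C@@H](O)[C@H]1O` gives 70 nM. Compound 4 `CN(C)c1ncnc2c1c(-c1cccs1)cn2[C@@H]1O[C@H](CO)[C@@H](O)[C@H]1O` differs from compound 3 by thiophen-2-yl in place of furan-3-yl on an aromatic carbon. Going by the values given here, the only measured step on the core of compound 3, a 14-fold higher number from compound 2 to compound 3 (1.15 log units; beyond the scatter), shows the furan-3-yl compound carrying the high number. Among the compounds with values here, no measured pair sets thiophen-2-yl directly against furan-3-yl; compound 1 bears thiophen-2-yl on a different core and its value is low. Compound 4 is therefore expected to fall well below compound 3, by a 5.1-fold lower number from compound 3 to compound 4 (0.71 log units; beyond the scatter), though the size is uncertain. Compound 4 is estimated at 300 nM with a range of 100 nM to 900 nM.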

Compound 4, half-maximal inhibitory concentration: > 20000 nM
Compound 4 gave a limit, no number (the forecaster's own chance of this, stated with the estimate: 2%); middle value at least 66-fold (1.82 log units) away from the limit.
By their numbers in this assay, from the lowest: compounds 1 and 2 (each within the scatter of the next); then compound 3. At a limit, above all of these: compound 4.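

In this assay compound 4 gives a limit, not a number: the limit of > 20000 nM in this assay, at which 1 of the 4 values shown sits.

Thiophen-2-yl and furan-3-yl have matching counts, yet the swap at this aromatic carbon gives an at least 12-fold higher number from compound 3 to compound 4 (1.11 log units; beyond the scatter). On the same core, replacing ethynyl gives an at least 180-fold higher number from compound 2 to compound 4 (2.25 log units; beyond the scatter). With thiophen-2-yl held fixed, the other change gives an at least 280-fold higher number from compound 1 to compound 4 (2.45 log units; beyond the scatter), so the low value of compound 1 does not carry over to the dimethylamino core.

As far as these compounds go, what an unsubstituted amine or a methyl group would give in place of dimethylamino alongside thiophen-2-yl stays open. So does the effect of a phenyl ring at this aromatic carbon.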